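Amide nitrogen substituent in the fused lactam series

This account rests on a few compounds, and the source may have more. Where it says the series, first, only, none or still open, it means among the compounds named here.

Measured in a functional assay on MCF7 cells (Homo sapiens) for antiproliferative activity, read by MTT assay, with a stated time of 72 h; a higher number here means a weaker inhibitor, a lower number a stronger inhibitor:
- compound 1 `COc1ncc(-c2ccc3c(c2)N(c2ccccc2)C(=O)CO3)cc1NS(=O)(=O)c1ccc(F)cc1` gives 8870 nM.
- compound 3 `COc1ncc(-c2ccc3c(c2)N(C2CC2)C(=O)CO3)cc1NS(=O)(=O)c1ccc(F)cc1` gives 35200 nM.
- compound 2 `O=C1COc2ccc(-c3cccc(NS(=O)(=O)c4ccc(F)cc4)c3)cc2N1c1ccccc1` gives only a limit, > 40000 nM.

Among the compounds with values here, the one counted change among the measured compounds is cyclopropyl in place of phenyl on an amide-type nitrogen in a ring, and it gives a 4.0-fold higher number from compound 1 to compound 3 (0.60 log units; beyond the scatter). How the core of compound 1 differs from the core of compound 2 is not broken down here; what the two values show is that compound 1 has a number while compound 2 sits at the limit of > 40000 nM in this assay, at which 1 of the 3 values shown sits.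

Compound 4 `O=C1COc2ccc(-c3cccc(NS(=O)(=O)c4ccc(F)cc4)c3)cc2N1C1CC1` is not yet measured. It stands to compound 2 as compound 3 stands to compound 1: cyclopropyl in place of phenyl on an amide-type nitrogen in a ring, the same change at the same place. Since compound 2 already sits at the limit and the same change on compound 1 moved the number upward, the step for compound 4 is expected to be a step that the limit leaves unreadable from compound 2 to compound 4, meaning a value again beyond the limit is expected. The estimate for compound 4 in this assay is 120000 nM, between 40000 nM and 400000 nM, most likely reported as a limit.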

Compound 4, half-maximal inhibitory concentration: > 40000 nM
Compound 4: no number, only a limit (the forecaster's own chance of this, stated with the estimate: 90%); the middle value is on the limit's open side.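

In this assay compound 4 gives > 40000 nM as a limit, not a number. Compound 2 gives > 40000 nM as a limit too. No step can be read between compound 2 and compound 4. The compounds shown leave open whether, and how far, cyclopropyl in place of phenyl on the amide-type nitrogen moves the number on the core of compound 2.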